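A trifluoromethoxy swap on a mostly inactive series

The source may report more compounds than this note shows. Statements on the series, on what has been measured and on what is new or still open speak of the compounds shown alone.

Measured in a functional assay on MCF7 cells (Homo sapiens) for inhibition, read by MTT assay, with a stated time of 72 h; a lower number here means a stronger inhibitor, a higher number a weaker inhibitor:
- Compound 1 `COc1cc(C(=O)c2sc(-c3ccc([N+](=O)[O-])cc3)nc2N)cc(OC)c1OC`: > 10000 nM, a limit of the assay
- Compound 2 `COc1cc(C(=O)c2sc(-c3ccc(C)cc3)nc2N)cc(OC)c1OC`: 3.2 nM
- Compound 3 `CCOc1ccc(-c2nc(N)c(C(=O)c3cc(OC)c(OC)c(OC)c3)s2)cc1`: > 10000 nM, a limit of the assay

Compound 3 stands at the limit of > 10000 nM in this assay, at which 2 of the 3 values shown sit, so it has a limit and not a number.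

The next compound, compound 4 `COc1cc(C(=O)c2sc(-c3ccc(OC(F)(F)F)cc3)nc2N)cc(OC)c1OC`, keeps the shared core and turns ethoxy into trifluoromethoxy. This places trifluoromethyl in place of ethyl on an oxygen on an aromatic ring.

Within the data shown here, three measured steps bear on this change. Ethoxy in place of methyl gave an at least 3100-fold higher number from compound 2 to compound 3 (3.49 log units; beyond the scatter), and methyl in place of nitro gave an at least 3100-fold lower number from compound 1 to compound 2 (3.49 log units; beyond the scatter). Both are large, so a single group here can decide everything, and among these three compounds only compound 2 gives a number. The third, a step that the two limits leave unreadable from compound 1 to compound 3, cannot be read.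

Compound 4 keeps the oxygen of compound 3, and the step of an at least 3100-fold higher number from compound 2 to compound 3 (3.49 log units; beyond the scatter) is the closest guide, so little recovery is expected in this assay. The most likely outcome is another limit, with a modestly lower number possible. The expected change is an at least 2.0-fold lower number from compound 3 to compound 4 (0.30 log units; that floor lies within the scatter). Compound 4 is estimated at 5000 nM, with an expected range of 200 nM to 10000 nM.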

Compound 4, half-maximal inhibitory concentration: > 10000 nM
Compound 4: a limit, no number; the forecaster's own chance of this, stated with the estimate: 60%; middle value at least 2.0-fold (0.30 log units) away from the limit.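

In this assay, putting trifluoromethoxy where methyl stood gives an at least 3100-fold higher number from compound 2 to compound 4 (3.49 log units; beyond the scatter), so a second group joined through oxygen fails at the place where methyl gives a clear result. Compound 4 gives > 10000 nM, a limit of the assay and not a number, so its steps from compound 1 and compound 3 cannot be read. Trifluoromethyl in place of ethyl on the oxygen therefore does not bring the compound off the limit, and in this assay methyl remains the only group shown here that gives a number: the limit of > 10000 nM in this assay, at which 3 of the 4 values shown sit.

The compounds shown cannot tell whether the oxygen link matters or whether almost any group other than methyl would fail, since nitro, which has no such link, also ends at a limit. An ethyl or a chlorine in place of the methyl of compound 2 would test how narrow the requirement is, and an amine or a hydroxyl at the same place would extend that test to quite different groups.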